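This account rests on a few compounds, and the source may have more. Where it says the series, first, only, none or still open, it means among the compounds named here.

Compound 1 is `COc1cc2c(cc1OC)C(c1ccc([N+](=O)[O-])cc1)=NNC(=O)C2`. In a functional assay on the whole organism with Mus musculus as the target (a higher number here means that more compound is needed for the effect, a lower number that less compound is needed), compound 1 gives > 120 umol/kg, which is a limit of the assay rather than a measured number. Compound 1 therefore stands at the limit of > 120 umol/kg in this assay, at which 1 of the 3 values shown sits, so how much compound it truly needs is not known. Two other members of the shared core have measured doses. Compound 2, `COc1cc2c(cc1OC)C(c1cccc(N)c1)=NN=C(S)C2`, gives 9.1 umol/kg in this assay. Compound 3, `COc1cc2c(cc1OC)C(c1ccc(Br)cc1)=NN(C)C(=S)C2`, gives 60.4 umol/kg in this assay. Going by the values given here, compound 2 and compound 3 each differ from compound 1 in more than one place at a time, so their values show only that compounds built on this core can reach a measurable dose; they do not isolate any single change.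

The compound now to be measured is compound 4, `COc1cc2c(cc1OC)C(c1ccccc1)=NNC(=O)C2`. It differs from compound 1 in one place: hydrogen in place of nitro on an aromatic carbon. Because compound 1 sits at the limit of > 120 umol/kg in this assay, at which 1 of the 3 values shown sits, the step to compound 4 cannot be read from a measured pair. The step is estimated as an at least 1.3-fold lower number from compound 1 to compound 4 (0.12 log units; that floor lies within the scatter), expected to go toward a lower dose, though with wide uncertainty. Compound 4 is expected to give about 90 umol/kg in this assay, with a likely range from 30 umol/kg to 300 umol/kg.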

Compound 4, dose for half-maximal effect: 31.8 umol/kg
Compound 4: middle estimate off by 2.8-fold (0.45 log units), on the high side; the range from low to high includes it.
By their numbers in this assay, from the lowest: compound 2; then compounds 4 and 3 (each within the scatter of the next). At a limit, above all of these: compound 1.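

Going by these compounds alone, removing the nitro group from the aromatic carbon, para to a large group, and leaving hydrogen there gives an at least 3.7-fold lower number from compound 1 to compound 4 (0.57 log units; beyond the scatter) in this assay, so this is the first single change on the shared core that can be read on its own. With hydrogen at this place, compound 4 gives 31.8 umol/kg, a measured number from which any later change at this position can be judged, whereas compounds 2 and 3 each differ from compound 1 in more than one place and could isolate nothing. The step fixes only a minimum size and its true size stays unknown, because compound 1 has no measured number to start from: the limit of > 120 umol/kg in this assay, at which 1 of the 4 values shown sits.

At this position the comparison covers only nitro and hydrogen, so one step cannot show whether the dose depends on nitro alone or would also shift with a nitrile, a carboxylic acid or a methyl group in the same place. It also leaves open whether the same change would give a step of similar size on a core carrying the thione of compound 3 in place of the carbonyl.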